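The source may report more compounds than this note shows. Statements on the series, on what has been measured and on what is new or still open speak of the compounds shown alone.

Measured so far in a functional assay on Mino cells (Homo sapiens) for cytotoxicity, read by MTT assay, with a stated time of 72 h; on this read-out higher numbers stand for weaker inhibition and lower numbers for stronger inhibition:
compound 1 `O=C1N=C(N2N=C(c3ccc(Br)cc3)CC2c2ccc(Cl)cc2)S/C1=C1\C(=O)Nc2ccc(Cl)cc21`, 7400 nM
compound 2 `CN(C)c1ccc(C2CC(c3ccc(Cl)cc3)=NN2C2=NC(=O)/C(=C3/C(=O)Nc4ccc(Br)cc43)S2)cc1`, 160 nM

Of these two numbers, compound 1 gives the higher one; compound 2 lies far below it, a gap beyond the usual scatter. Compound 3 `O=C1N=C(N2N=C(c3ccc(Cl)cc3)CC2c2ccc(Cl)cc2)S/C1=C1\C(=O)Nc2ccc(Cl)cc21` differs from compound 1 in a single place: chloro in place of bromo on an aromatic carbon. Among the measured compounds shown here, no measured pair shows this exact swap, so the expected step is a 1.1-fold lower number from compound 1 to compound 3 (0.02 log units; within the scatter), small, within the scatter and with no clear direction. Compound 3 is therefore expected to give about 7000 nM in this assay, within a range of 2500 nM to 20000 nM.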

Compound 3, half-maximal inhibitory concentration: 80700 nM
Estimate against measurement, compound 3: 12-fold (1.06 log units) below, and the stated range ends below it.
By their numbers in this assay, from the lowest: compound 2; then compound 1; then compound 3.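

On the aromatic ring of compound 1, this position is highly sensitive: the change from 4-bromophenyl to 4-chlorophenyl, a swap of one halogen atom, gives an 11-fold higher number from compound 1 to compound 3 (1.04 log units; beyond the scatter) in this assay. Compounds 1 and 2 differ in more than one place, so they could not single out this position. Nothing available explains why so small a change has so large an effect.

Still open, from the compounds shown here alone, is how fluoro, methoxy or an amine would behave at this position. Also open, going by these compounds, is whether bromo in place of chloro at the same position would give a similar step in compound 2.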